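Capping the ring amine: working notes toward compound 3

This account rests on a few compounds, and the source may have more. Where it says the series, first, only, none or still open, it means among the compounds named here.

Among the measured compounds shown here, compound 1 `COc1cc(Cn2cc(CSC(=S)N3CCNCC3)nn2)cc(OC)c1OC` is known in a functional assay on ECa-109 cells (Homo sapiens) for inhibition, read by MTT assay, with a stated time of 72 h (a lower number here means a stronger inhibitor, a higher number a weaker inhibitor), only as a limit: compound 1 gives > 128000 nM, which is a limit of the assay rather than a number, so its standing among the values measured so far is bounded on one side only (the limit of > 128000 nM in this assay, at which 1 of the 2 values shown sits). For the measured compounds named here, compound 2 `COc1ccc(Cn2cc(CSC(=S)N3CCN(C(=O)OC(C)(C)C)CC3)nn2)cc1` differs from compound 1 in two places, and no step between the pair is measured; in this assay compound 2 gives 36800 nM, a number rather than a limit, and that is all the pair shows.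

Compound 3 `COc1cc(Cn2cc(CSC(=S)N3CCN(C(=O)OC(C)(C)C)CC3)nn2)cc(OC)c1OC` carries the change (tert-butoxycarbonyl in place of hydrogen on an amine nitrogen in a ring). Going by the values given here, no measured step covers this change on its own. In this assay, among the compounds with values here, the expected direction is toward stronger inhibition, drawn from compound 2, whose value 36800 nM is the one number seen for a compound bearing tert-butoxycarbonyl on the ring amine. The size of the step is uncertain, and the estimated step of an at least 2.8-fold lower number from compound 1 to compound 3 (0.45 log units; beyond the scatter) should be read with that in mind. Compound 3 is expected at 45000 nM, with a range from 15000 nM to 140000 nM, and some chance that the assay again reports only a limit.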

Compound 3, half-maximal inhibitory concentration: 44400 nM
Beside the measured number, compound 3's estimate is 1.0-fold (0.01 log units) above it; the range from low to high includes it.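

In this assay, tert-butoxycarbonyl in place of hydrogen on the amine nitrogen in the ring now stands as a single change on the core of compound 1, and it gives an at least 2.8-fold lower number from compound 1 to compound 3 (0.45 log units; beyond the scatter). The earlier pair differed in two places and could not separate this change from the other difference, whereas here the capped ring amine is the only difference, and the capped compound returns a number rather than a limit. The step is a bound and not a full size, and its true extent remains unknown because the uncapped compound 1 is reported only as a limit: the limit of > 128000 nM in this assay, at which 1 of the 3 values shown sits.

On these data alone, whether the shift belongs to tert-butoxycarbonyl itself or to any cap on that nitrogen remains open, and an acetyl, methyl or benzyl group at the same place would separate the two readings. The compounds shown also leave open whether a cap ending in a carboxylic acid, or one with a longer chain, would move the number further in this assay.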